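Ring for Bromine: Estimating Compound 3 in Acid Amidase Inhibition

The compounds below may be only part of what the source reports. "The series", "measured", "known", "first", "only" and "open" are said of these compounds alone.

Measured so far:
compound 1 `N#CN1CC(OCc2ccc(Oc3ccccc3)cc2)C1` gives 1.1 nM
compound 2 `N#CN1CC(OCc2ccc(Oc3ccccc3)cc2Br)C1` gives 1.03 nM

Compound 2 stands at the lowest of the two numbers in an assay on isolated protein for inhibition of N-acylethanolamine-hydrolyzing acid amidase (Homo sapiens), read by fluorescence, with a stated time of 90 min (a lower number here means a stronger inhibitor, a higher number a weaker inhibitor), though its nearest neighbour compound 1 lies within the scatter of it. Compound 3 `N#CN1CC(OCc2ccc(Oc3ccccc3)cc2-c2ccccc2)C1` carries phenyl in place of bromo on an aromatic carbon. Within the data shown here, the only measured step at this carbon, a 1.1-fold lower number from compound 1 to compound 2 (0.03 log units; within the scatter), shows that changing this position did not move the number beyond the scatter; no phenyl at any position has been measured. A step of comparable modest size is therefore expected, a 1.9-fold higher number from compound 2 to compound 3 (0.29 log units; within the scatter), with a wider uncertainty. Compound 3 is estimated at 2 nM, between 0.5 nM and 10 nM.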

Compound 3, half-maximal inhibitory concentration: 8.5 nM
The estimate for compound 3 lay 4.3-fold (0.63 log units) below the measured number; the measured number falls inside the stated range.
By their numbers in this assay, from the lowest: compounds 2 and 1 (each within the scatter of the next); then compound 3.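

At this aromatic carbon the outcome depends on the group: where bromo had left the number within the scatter, phenyl raises it in this assay (an 8.3-fold higher number from compound 2 to compound 3 (0.92 log units; beyond the scatter)). The rise also holds against the unsubstituted parent (a 7.7-fold higher number from compound 1 to compound 3 (0.89 log units; beyond the scatter)), so the change from one heavy atom to the six of phenyl separates compound 3 from both earlier compounds. No measurement shown here explains this rise. The compounds shown leave open how a methyl, a methoxy or an amine at this carbon would read. They also leave open whether a phenyl elsewhere on this ring would raise the number as well.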